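Trifluoromethoxy in place of trifluoromethyl on compound 2

The source may report more compounds than this note shows. Statements on the series, on what has been measured and on what is new or still open speak of the compounds shown alone.

Compound 1 `CC(O)(COc1cccc(C(F)(F)F)c1)C(=O)Nc1ccc(S(F)(F)(F)(F)F)cc1` gives 24700 nM
Compound 2 `CC(O)(COc1ccccc1C(F)(F)F)C(=O)Nc1ccc(S(F)(F)(F)(F)F)cc1` gives 1200 nM

In a functional assay on LNCaP cells (Homo sapiens) for antiproliferative activity, read by propidium iodide staining, with a stated time of 96 h (on this read-out higher numbers stand for weaker inhibition and lower numbers for stronger inhibition), compound 2 holds the lower of the two numbers, at 1200 nM. Compound 3 `CC(O)(COc1ccccc1OC(F)(F)F)C(=O)Nc1ccc(S(F)(F)(F)(F)F)cc1` carries trifluoromethoxy in place of trifluoromethyl on an aromatic carbon, ortho to a large group: trifluoromethoxy in place of trifluoromethyl on an aromatic carbon. Among the compounds with values here, the only measured step, a 21-fold lower number from compound 1 to compound 2 (1.31 log units; beyond the scatter), is large, but it shifts the place of the trifluoromethyl group and does not exchange that group. Within the data shown here, it therefore bears only indirectly, and no measured step tests this exchange. Only a small change in this assay, towards a slightly higher number, is expected: a 1.5-fold higher number from compound 2 to compound 3 (0.18 log units; within the scatter). The estimated value for compound 3 is 1800 nM, with a range of 500 nM to 6000 nM.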

Compound 3, half-maximal inhibitory concentration: 8900 nM
Compound 3: middle estimate off by 4.9-fold (0.69 log units), on the low side; measured number above the stated range.
By their numbers in this assay, from the lowest: compound 2; then compound 3; then compound 1.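

In this assay, the exchange of trifluoromethyl for trifluoromethoxy on this aromatic carbon, ortho to a large group, gives a 7.4-fold higher number from compound 2 to compound 3 (0.87 log units; beyond the scatter) and so is not a neutral swap. This position therefore responds not only to where the trifluoromethyl group sits but also to which group stands there. No measurement at hand accounts for this loss. As far as these compounds go, whether a nitrile or a methoxy group at this place would match compound 2 stays open. So does whether the same exchange would act alike at the position carrying trifluoromethyl in compound 1.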